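Adding a second chloro to compound 1

This account rests on a few compounds, and the source may have more. Where it says the series, first, only, none or still open, it means among the compounds named here.

Values in a functional assay on TSGH 8302 cells (Homo sapiens) for cytotoxicity; a higher number here means a weaker inhibitor, a lower number a stronger inhibitor:
Compound 1 `Cc1c(S(=O)(=O)N/C(=N\O)Nc2ccc(Cl)cc2)sc2ccc(Cl)cc12` gives 44 ug/mL
Compound 2 `O=S(=O)(N/C(=N\O)Nc1ccc(Cl)cc1)c1ccc(-c2cccs2)cn1` gives 208 ug/mL
Compound 3 `O=S(=O)(N/C(=N\O)Nc1ccc(Cl)cc1)c1cc(S(=O)(=O)c2ccccc2)cs1` gives 37 ug/mL

Compound 1 and compound 3 lie within the usual scatter of each other, while compound 2 stands clearly higher, and so weaker, than compound 1. Compound 4 `Cc1c(S(=O)(=O)N/C(=N\O)Nc2ccc(Cl)c(Cl)c2)sc2ccc(Cl)cc12` differs from compound 1 in one place: chloro in place of hydrogen on an aromatic carbon. This is chloro in place of hydrogen on an aromatic carbon, turning 4-chlorophenyl into 3,4-dichlorophenyl. Going by the values given here, no two measured compounds differ in just one place, so the data offer no direct guide. A modest fall in this assay is expected, though it may not clear the scatter. The expected change is a 1.6-fold lower number from compound 1 to compound 4 (0.20 log units; within the scatter). Compound 4 is estimated at 28 ug/mL, with a range of 10 ug/mL to 75 ug/mL.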

Compound 4, half-maximal inhibitory concentration: > 300 ug/mL
Compound 4: no number, only a limit (the forecaster's own chance of this, stated with the estimate: 5%); at least 10-fold (1.02 log units) between middle value and limit.
By their numbers in this assay, from the lowest: compounds 3 and 1 (each within the scatter of the next); then compound 2. At a limit, above all of these: compound 4.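

In this assay compound 4 gives > 300 ug/mL, which is a limit of the assay and not a number. The change from 4-chlorophenyl to 3,4-dichlorophenyl therefore gives an at least 6.8-fold higher number from compound 1 to compound 4 (0.83 log units; beyond the scatter). From the compounds shown here alone, this shows that this aromatic carbon is sensitive to substitution: one chloro in place of hydrogen is enough to weaken the compound clearly, although the full size of the step remains unknown.

Going by these compounds, whether a fluoro, methyl or methoxy group on this carbon would have the same effect remains open. So does whether chloro here would weaken compound 2 or compound 3 in the same way.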